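Azetidinyl Amides on a Bis-Sulfonamide Piperidine Core

The source may hold more compounds than are shown below. What is called first, only, known or untested is meant among the compounds shown, and "the series" means these compounds.

The measured compounds are these. Compound 1, `CCN1CC(NC(=O)[C@@H]2CCCN(S(=O)(=O)c3ccc(S(=O)(=O)N(CC)CC)cc3)C2)C1`, in a functional assay on MIA PaCa-2 cells (Homo sapiens) for inhibition, read by MTT assay, with a stated time of 7 days (on this read-out higher numbers stand for weaker inhibition and lower numbers for stronger inhibition), gives > 30000 nM, which is a limit of the assay and not a number. Compound 2, `CCN(CC)S(=O)(=O)c1ccc(S(=O)(=O)N2CCC[C@@H](C(=O)NC)C2)cc1`, in this assay gives 8600 nM.

Going by the values given here, compound 2 thus holds the only numerical value in this assay; the other result is a limit, (the limit of > 30000 nM in this assay, at which 1 of the 2 values shown sits). Among the compounds with values here, the one measured step, an at least 3.4-fold lower number from compound 1 to compound 2 (0.54 log units; beyond the scatter), shows that trading the 1-ethylazetidin-3-yl group for methyl on the amide nitrogen moved the number downward.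

Compound 3, `CCN(CC)S(=O)(=O)c1ccc(S(=O)(=O)N2CCC[C@@H](C(=O)NC3CN(C(=O)NC(C)(C)C)C3)C2)cc1`, differs from compound 2 by 1-((tert-butyl)carbamoyl)azetidin-3-yl in place of methyl on an amide-type nitrogen. This change runs in the opposite sense to the measured step: an azetidin-3-yl group returns to the amide nitrogen, now bearing a tert-butylcarbamoyl group rather than ethyl. Within the data shown here, only the step from compound 1 to compound 2 bears on it, and that step was at least modest. Compound 3 is therefore expected to show a step of a 2.3-fold higher number from compound 2 to compound 3 (0.37 log units; beyond the scatter) in this assay, toward weaker inhibition. The estimate for compound 3 is 20000 nM, with a range from 6000 nM to 60000 nM.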

Compound 3, half-maximal inhibitory concentration: 3400 nM
Compound 3: the middle estimate sits 5.9-fold (0.77 log units) above what was measured, outside the stated range (below it).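

Going by these compounds alone, the azetidin-3-yl group on the amide nitrogen does not by itself go with a higher number in this assay: 1-((tert-butyl)carbamoyl)azetidin-3-yl in place of methyl gives a 2.5-fold lower number from compound 2 to compound 3 (0.40 log units; beyond the scatter), a direction opposite to the one the first step might have suggested for such a group. What is attached to the amine nitrogen in the ring therefore matters at this position, since (tert-butyl)carbamoyl in place of ethyl gives an at least 8.8-fold lower number from compound 1 to compound 3 (0.94 log units; beyond the scatter). Compound 1 stands at a limit of the assay and not at a number, so this second step has no upper end: the limit of > 30000 nM in this assay, at which 1 of the 3 values shown sits.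

The compounds shown do not separate the contribution of the carbonyl and amide hydrogen of the carbamoyl part from that of the tert-butyl group, as ethyl and (tert-butyl)carbamoyl are the only two groups on that ring nitrogen here. Going by these compounds, it remains open where an acetyl, a methylcarbamoyl, a simple tert-butyl or a free amine on that nitrogen would fall relative to compound 1 and compound 3.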